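From carbamoyl to methyl on the piperazine ring

The compounds below may be only part of what the source reports. "The series", "measured", "known", "first", "only" and "open" are said of these compounds alone.

In an ADME assay for permeability, using PAMPA, with a stated time of 4 h, at pH 7.4 (on this read-out higher numbers stand for higher permeability and lower numbers for lower permeability), compound 3 (`NC(=O)N1CCN(CCCN(C[C@H]2Cc3ccccc3CN2)[C@H]2CCCc3cccnc32)CC1`) gives 67 nm/s, the highest of three values, compared with compound 1 (`c1ccc2c(c1)CN[C@@H](CN(CCC1CCNCC1)[C@H]1CCCc3cccnc31)C2`) at 19 nm/s and compound 2 (`c1ccc2c(c1)CN[C@@H](CN(CCN1CCNCC1)[C@H]1CCCc3cccnc31)C2`) at 10 nm/s. Compound 4 (`CN1CCN(CCCN(C[C@H]2Cc3ccccc3CN2)[C@H]2CCCc3cccnc32)CC1`) has methyl in place of carbamoyl on an amine nitrogen in a ring. Within the data shown here, no measured step makes this exact change. The closest evidence comes from two steps that introduce the carbamoyl-bearing side chain: a 3.5-fold higher number from compound 1 to compound 3 (0.55 log units; beyond the scatter) and a 6.7-fold higher number from compound 2 to compound 3 (0.83 log units; beyond the scatter). Both steps also alter the chain, so only part of their size is expected to carry over. A modest fall is therefore expected in this assay, with an estimated 1.9-fold lower number from compound 3 to compound 4 (0.28 log units; within the scatter). Compound 4 is expected at 35 nm/s, within an estimated range of 12 nm/s to 100 nm/s.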

Compound 4, apparent permeability: 360 nm/s
Compound 4: the middle estimate sits 10-fold (1.01 log units) below what was measured; measured number above the stated range.
By their numbers in this assay, from the lowest: compounds 2 and 1 (each within the scatter of the next); then compound 3; then compound 4.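

In this assay, methyl in place of carbamoyl on the amine nitrogen in the ring gives a 5.4-fold higher number from compound 3 to compound 4 (0.73 log units; beyond the scatter), so carbamoyl is not needed for the top number in this set. The two longer comparisons, a 36-fold higher number from compound 2 to compound 4 (1.56 log units; beyond the scatter) and a 19-fold higher number from compound 1 to compound 4 (1.28 log units; beyond the scatter), are larger, but they also change the chain. Nothing measured here explains the rise. On these data alone, whether it is specific to methyl remains open, since an ethyl or acetyl group on the same nitrogen would test that. It is also unclear whether 4-methylpiperazin-1-yl on a shorter chain would give a similar number.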